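Methyl for Hydrogen on an Aromatic Carbon in Three Analogues

A few compounds are considered here, and "the series" means these few. Any claim that something is new, unique, unknown or untested is made for them only; others in the source may bear on it.

Measured compounds:
compound 1, `N/C(=N\NC(=S)N1CCCCCC1)c1ccccn1`: 82.9%
compound 2, `Cc1cccc(/C(N)=N/NC(=S)N2CCSCC2)n1`: 85.3%
compound 3, `N/C(=N\NC(=S)N1CCSCC1)c1ccccn1`: 80.6%

All three were tested in a functional assay on HeLa cells (Homo sapiens) for cytotoxicity, read by MTT assay, with a stated time of 72 h, tested at 30 uM; a higher number here means more inhibition of growth at the concentration tested, a lower number less inhibition of growth. In this assay compound 1 gives 82.9%, and compound 3 gives 80.6%; the two numbers lie within the scatter of each other, so nothing can be said about their order. Compound 2 differs from compound 3 by methyl in place of hydrogen on an aromatic carbon, and this change made a number 4.7 percentage points higher from compound 3 to compound 2 (within the scatter). The difference between the core of compound 1 and the core of compound 3 is not broken down here.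

Compound 4, `Cc1cccc(/C(N)=N/NC(=S)N2CCCCCC2)n1`, has not yet been measured. It differs from compound 1 by methyl in place of hydrogen on an aromatic carbon, the same change as from compound 3 to compound 2, at a place described in the same words. Since that step stayed within the scatter, compound 4 is expected to show a number 2.1 percentage points higher from compound 1 to compound 4 (within the scatter), an expectation that rests on a number 4.7 percentage points higher from compound 3 to compound 2 (within the scatter) and on compound 1 giving 82.9%. The estimate for compound 4 in this assay is 85%, expected to fall between 75% and 92%.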

Compound 4, percent growth inhibition at one concentration: 81.2%
For compound 4 the middle estimate is 3.8 percentage points above the measured one; low and high end bracket the measured number.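

In this assay, methyl in place of hydrogen on an aromatic carbon of the core of compound 1 gave a number 1.7 percentage points lower from compound 1 to compound 4 (within the scatter). Set beside the earlier case, the change shows no difference between the two cores that can be told from the scatter: the same change on two cores in this assay, a number 4.7 percentage points higher (within the scatter) from compound 3 to compound 2 and a number 1.7 percentage points lower (within the scatter) from compound 1 to compound 4, 6.4 percentage points apart, within the scatter of two such steps. The pair of steps is therefore consistent with the change carrying from one core to the other, and neither step shows that the methyl moves the number at all, but two small steps cannot show that the change behaves identically on both cores, and they say nothing about any further core.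

The compounds shown leave open what an amine, a methoxy group or a carboxylic acid would give in place of the methyl on that aromatic carbon, next to the ring nitrogen. They also leave open whether a longer chain there would give a step that stands clear of the scatter.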